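This account rests on a few compounds, and the source may have more. Where it says the series, first, only, none or still open, it means among the compounds named here.

Measured in an assay on isolated protein for binding affinity to adenosine receptor A3 (Homo sapiens); a lower number here means a stronger inhibitor, a higher number a weaker inhibitor:
compound 1, `CNC(=O)[C@H]1O[C@@H](n2cnc3c(NCc4cc(Cl)ccc4OC)ncnc32)[C@H](O)[C@@H]1N`: 15 nM
compound 2, `CNC(=O)[C@H]1O[C@@H](n2cnc3c(NCc4cc(Cl)ccc4OCc4ccccc4)ncnc32)[C@H](O)[C@@H]1N`: 16 nM
compound 3, `CNC(=O)[C@H]1O[C@@H](n2cnc3c(NCc4cc(Cl)ccc4OCC(N)=O)ncnc32)[C@H](O)[C@@H]1N`: 6.8 nM

Compound 3 gives the lowest of the three numbers, and both of its steps are beyond the scatter: a 2.2-fold lower number from compound 1 to compound 3 (0.34 log units; beyond the scatter) and a 2.4-fold lower number from compound 2 to compound 3 (0.37 log units; beyond the scatter). Compound 3 is therefore the strongest binder of the three in this assay. Compound 4, `CNC(=O)[C@H]1O[C@@H](n2cnc3c(NCc4cc(Cl)ccc4OCC(=O)N4CCCCC4)ncnc32)[C@H](O)[C@@H]1N`, differs from compound 3 by piperidin-1-yl in place of amino on a carbonyl carbon. The two modest steps just named bear on this change only in that they show the carbamoyl at the oxygen-bound carbon brought a lower number than hydrogen or phenyl. The step of a 1.1-fold higher number from compound 1 to compound 2 (0.03 log units; within the scatter) shows that a larger group on that carbon left this assay unchanged. Within the data shown here, no measured step replaces the amino on the carbonyl, so the direction is uncertain; the expected step for compound 4 is a 1.5-fold higher number from compound 3 to compound 4 (0.17 log units; within the scatter), within the scatter. Compound 4 is expected at 10 nM, with a range from 4 nM to 30 nM.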

Compound 4, inhibition constant: 18 nM
Compound 4: middle estimate off by 1.8-fold (0.26 log units), on the low side; measured number inside the range.
By their numbers in this assay, from the lowest: compound 3; then compounds 1, 2 and 4 (each within the scatter of the next).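

In this assay the group on the carbonyl carbon matters: piperidin-1-yl in place of amino gives a 2.6-fold higher number from compound 3 to compound 4 (0.42 log units; beyond the scatter), a modest step that removes the advantage of compound 3. That advantage therefore belongs to the carbamoyl and does not carry over to the (piperidin-1-yl)carbonyl group, which reads a 1.2-fold higher number from compound 1 to compound 4 (0.08 log units; within the scatter) and a 1.1-fold higher number from compound 2 to compound 4 (0.05 log units; within the scatter), both within the scatter and so no different from hydrogen or phenyl on that carbon. No supporting measurement bears on why the step occurs.

This one change removes a hydrogen-bond donor and brings in a six-membered non-aromatic ring, and the compounds shown do not separate the two. Open too, as far as these compounds go, is how methylamino, dimethylamino or morpholin-4-yl on the carbonyl would read here.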